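Trichloromethyl in Place of Tert-Butyl: Expected Antiproliferative Shift

This account rests on a few compounds, and the source may have more. Where it says the series, first, only, none or still open, it means among the compounds named here.

Measured compounds:
compound 1 `O=C(CCl)Nc1ccc(SCC(=O)Nc2ccc(Cl)cn2)cc1`: 420 nM
compound 2 `O=C(CCCCl)Nc1ccc(SCC(=O)Nc2ccc(Cl)cn2)cc1`: > 80000 nM, a limit of the assay
compound 3 `CC(C)(C)C(=O)Nc1ccc(SCC(=O)Nc2ccc(Cl)cn2)cc1`: 67200 nM

In a functional assay on NCI-H460 cells (Homo sapiens) for antiproliferative activity, read by MTT assay, with a stated time of 48 h (on this read-out lower numbers stand for stronger inhibition and higher numbers for weaker inhibition), compound 3 gives 67200 nM, the highest of the two numbers shown, while compound 1 gives 420 nM. For compound 2 the assay reports only a limit, > 80000 nM. Compound 4 `O=C(CSc1ccc(NC(=O)C(Cl)(Cl)Cl)cc1)Nc1ccc(Cl)cn1` differs from compound 3 in one place: trichloromethyl in place of tert-butyl on a carbonyl carbon. Going by the values given here, two measured steps touch tert-butyl on that carbonyl carbon: a 160-fold higher number from compound 1 to compound 3 (2.20 log units; beyond the scatter) and an at least 1.1-fold lower number from compound 2 to compound 3 (0.07 log units; that floor lies within the scatter). The former shows that replacing chloromethyl by tert-butyl raised the number greatly; the latter lies within the scatter. Trichloromethyl brings chlorine back at the same heavy-atom count as tert-butyl, so the expected step is a 4.5-fold lower number from compound 3 to compound 4 (0.65 log units; beyond the scatter), though with wide uncertainty. Compound 4 is estimated at 15000 nM, between 1500 nM and 90000 nM.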

Compound 4, half-maximal inhibitory concentration: > 80000 nM
Compound 4 ended at the assay's limit; the forecaster's own chance of this, stated with the estimate: 20%; middle value at least 5.3-fold (0.72 log units) away from the limit.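

The value of compound 4 is a limit of the assay, not a number. Trichloromethyl in place of chloromethyl gives an at least 190-fold higher number from compound 1 to compound 4 (2.27 log units; beyond the scatter), so chlorine on this carbon does not by itself keep the low number of compound 1. Trichloromethyl in place of tert-butyl gives an at least 1.1-fold higher number from compound 3 to compound 4 (0.07 log units; that floor lies within the scatter), which shows no gain over tert-butyl.

On these data alone, the step between compound 2 and compound 4 cannot be read, since both sit at the same ceiling: the limit of > 80000 nM in this assay, at which 2 of the 4 values shown sit. What bromomethyl on this carbonyl carbon would give remains open.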